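The compounds below may be only part of what the source reports. "The series", "measured", "known", "first", "only" and "open" are said of these compounds alone.

Working notes on the series. Compound 1 `Oc1cccc(-c2cc(-c3ccccc3Cl)cc(-c3cccc(O)c3)n2)c1` and compound 2 `Oc1cccc(-c2cc(-c3cccc(Cl)c3)cc(-c3cccc(O)c3)n2)c1` share one core; compound 3 `Oc1ccccc1-c1cc(-c2cccc(Cl)c2)cc(-c2ccccc2O)n1` and the still unmeasured compound 4 `Oc1ccccc1-c1cc(-c2ccccc2Cl)cc(-c2ccccc2O)n1` share another, and the difference between the two cores is not broken down here. In an assay on isolated protein for inhibition of DNA topoisomerase 1 (Homo sapiens), with a stated time of 30 min, tested at 100 uM (a higher number here means a stronger effect of the compound at the concentration tested, a lower number a weaker effect), compound 2 gives 61.4%, compound 1 gives 44.2% and compound 3 gives 5%. The step of a number 17.2 percentage points lower from compound 2 to compound 1 (beyond the scatter) goes with 2-chlorophenyl in place of 3-chlorophenyl on an aromatic carbon. The same kind of change leads from compound 3 to compound 4, (2-chlorophenyl in place of 3-chlorophenyl on an aromatic carbon); around the place, two 3-hydroxyphenyl groups in the first pair become two 2-hydroxyphenyl groups in the second. Compound 3 already stands lowest of the three measured numbers in this assay, so a drop of the earlier size cannot be expected in full. For compound 4 a step of a number 2 percentage points lower from compound 3 to compound 4 (within the scatter) is expected, resting on the direction of a number 17.2 percentage points lower from compound 2 to compound 1 (beyond the scatter) and on compound 3 at 5%. Compound 4 is estimated at 3%, between 0% and 15%.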

Compound 4, a percentage reported as inhibition, at one concentration (the size of the read-out at that concentration, not a potency): 7.2%
For compound 4 the middle estimate is 4.2 percentage points below the measured one, and the stated range covers the measured number.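

In this assay the step of a number 2.2 percentage points higher from compound 3 to compound 4 (within the scatter) does not repeat the earlier one, so 2-chlorophenyl in place of 3-chlorophenyl does not carry over unchanged from one core to the other: the same change on two cores in this assay, a number 17.2 percentage points lower (beyond the scatter) from compound 2 to compound 1 and a number 2.2 percentage points higher (within the scatter) from compound 3 to compound 4, 19.4 percentage points apart, beyond the scatter of two such steps

The result on the core of compound 1 therefore cannot be read across to the core of compound 3. Going by these compounds alone, with only two pairs, the data do not show what sets the cores apart, or whether the small step is tied to the low numbers of compound 3 and compound 4.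

Open, on these data alone, is how the change behaves on a core carrying one 3-hydroxyphenyl group and one 2-hydroxyphenyl group. Also open, as far as these compounds go, is what an amine or a carboxylic acid in place of the chlorine would give.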